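Swapping a dimethoxyphenyl for a trifluoromethylphenyl

This account rests on a few compounds, and the source may have more. Where it says the series, first, only, none or still open, it means among the compounds named here.

Compound 1, `COc1ccc(C(=O)c2cc(OC)c(OC)c(OC)c2)cc1NC(=O)/C=C/c1ccc(OC)c(OC)c1`: 6300 nM
Compound 2, `COc1ccc(/C=C/C(=O)Nc2cc(C(=O)c3cc(OC)c(OC)c(OC)c3)ccc2OC)cc1`: 8700 nM
Compound 3, `COc1cccc(/C=C/C(=O)Nc2cc(C(=O)c3cc(OC)c(OC)c(OC)c3)ccc2OC)c1`: 3100 nM

These three share one core and differ only in the ring at the far end of the amide chain. In a functional assay on B16 cells (Mus musculus) for cytotoxicity, read by MTT assay, with a stated time of 72 h (a higher number here means a weaker inhibitor, a lower number a stronger inhibitor), compound 1 gives 6300 nM, the second highest of the three values; compound 2 lies within the scatter of it (a 1.4-fold higher number from compound 1 to compound 2 (0.14 log units; within the scatter)), while compound 3 is modestly lower (a 2.0-fold lower number from compound 1 to compound 3 (0.31 log units; beyond the scatter)). Compound 4, `COc1ccc(C(=O)c2cc(OC)c(OC)c(OC)c2)cc1NC(=O)/C=C/c1ccc(C(F)(F)F)cc1`, carries a different change: 4-(trifluoromethyl)phenyl in place of 3,4-dimethoxyphenyl on a double-bonded chain carbon bound to a double-bonded chain carbon. For the measured compounds named here, the steps of a 1.4-fold higher number from compound 1 to compound 2 (0.14 log units; within the scatter) and a 2.0-fold lower number from compound 1 to compound 3 (0.31 log units; beyond the scatter) show that removing one methoxy group shifts the value little, and a 2.8-fold lower number from compound 2 to compound 3 (0.45 log units; beyond the scatter) is also modest, but no measured step introduces a trifluoromethyl group. Compound 4 is therefore expected to show only a small step, a 1.3-fold lower number from compound 1 to compound 4 (0.10 log units; within the scatter), from its parent. The estimate for compound 4 is 5000 nM, within 1500 nM to 20000 nM.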

Compound 4, half-maximal inhibitory concentration: 100 nM
For compound 4 the middle estimate is 50-fold (1.70 log units) above the measured one; the measured number lies below the stated range.
By their numbers in this assay, from the lowest: compound 4; then compound 3; then compounds 1 and 2 (each within the scatter of the next).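

In this assay, the ring at the end of the double-bonded chain matters far more than the methoxy changes suggested: 4-(trifluoromethyl)phenyl in place of 3,4-dimethoxyphenyl gives a 63-fold lower number from compound 1 to compound 4 (1.80 log units; beyond the scatter). The drop also appears against the two singly substituted rings, with a 31-fold lower number from compound 3 to compound 4 (1.49 log units; beyond the scatter) and an 87-fold lower number from compound 2 to compound 4 (1.94 log units; beyond the scatter), the latter a swap of methoxy for trifluoromethyl on an aromatic carbon. Nothing measured here explains this large drop. The compounds shown leave open whether a nitrile, a chlorine atom or a methyl group in place of trifluoromethyl would give a similarly low number.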